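This account rests on a few compounds, and the source may have more. Where it says the series, first, only, none or still open, it means among the compounds named here.

In a functional assay on HT-29 cells (Homo sapiens) for inhibition, read by sulforhodamine B assay, with a stated time of 72 h (a lower number here means a stronger inhibitor, a higher number a weaker inhibitor), compound 3 `COc1ccc(C2C(Oc3ccccc3)C(=O)N2c2cc(OC)c(OC)c(OC)c2)cc1` gives 52 nM, within the usual scatter of compound 2 `CCOc1ccc(C2C(C3CC3)C(=O)N2c2cc(OC)c(OC)c(OC)c2)cc1` at 63 nM. For the measured compounds named here, compound 1 `COc1ccc(C2C(O)C(=O)N2c2cc(OC)c(OC)c(OC)c2)cc1` gives 12 nM, and the one measured single-place step, a 4.3-fold higher number from compound 1 to compound 3 (0.64 log units; beyond the scatter), lies beyond the scatter. Compound 4 `COc1ccc(C2C(C3CC3)C(=O)N2c2cc(OC)c(OC)c(OC)c2)cc1` brings a new change: cyclopropyl in place of phenoxy on a saturated ring carbon. That measured step acts on the same ring carbon, but it does not cover this swap. The closest guide is compound 2 at 63 nM, which also carries cyclopropyl there but differs from compound 4 elsewhere. No step beyond the scatter is therefore expected in this assay, with a slight lean towards a lower number. The expected change is a 1.6-fold lower number from compound 3 to compound 4 (0.21 log units; within the scatter). For compound 4 the estimate is 32 nM, with an expected range of 10 nM to 100 nM.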

Compound 4, half-maximal inhibitory concentration: 107 nM
Compound 4: middle estimate off by 3.3-fold (0.52 log units), on the low side; measured number above the stated range.
By their numbers in this assay, from the lowest: compound 1; then compounds 3, 2 and 4 (each within the scatter of the next, the first and the last beyond it).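

On this saturated ring carbon, this assay shows that the smaller cyclopropyl does not keep up with phenoxy, giving a 2.1-fold higher number from compound 3 to compound 4 (0.31 log units; beyond the scatter). Cyclopropyl in place of hydroxy gives the larger 8.9-fold higher number from compound 1 to compound 4 (0.95 log units; beyond the scatter), so of these three groups hydroxy gives the lowest number. Elsewhere, hydrogen in place of methyl on a saturated chain carbon bound to an oxygen on an aromatic ring gives a 1.7-fold higher number from compound 2 to compound 4 (0.23 log units; within the scatter). Nothing available explains why these groups rank this way. Going by these compounds, how an amine, a carboxylic acid or a longer chain on this ring carbon would compare stays open.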